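The source may report more compounds than this note shows. Statements on the series, on what has been measured and on what is new or still open speak of the compounds shown alone.

Compound 1 `Cc1nc2cc(C(F)(F)F)ccc2n1-c1ccc(C(=O)NC2CC2)s1`, compound 2 `Cc1cc(F)c2ncn(-c3ccc(C(=O)NC4CC4)s3)c2c1` and compound 3 `O=C(NC1CC1)c1ccc(-n2cnc3cc(C(F)(F)F)ccc32)s1` have all been measured. In an in vitro ADME assay on microsomes from liver (Homo sapiens) for pharmacokinetics, read by LC-MS (a lower number here means slower removal, a higher number faster removal of the compound), compound 1 gives 4 mL/min/kg, compound 3 gives 8 mL/min/kg and compound 2 gives 10 mL/min/kg. Compound 3 differs from compound 1 by hydrogen in place of methyl on an aromatic carbon, a change that produced a 2.0-fold higher number from compound 1 to compound 3 (0.30 log units; within the scatter). How the cores of compound 1 and compound 2 differ is not broken down here. Compound 4 `O=C(NC1CC1)c1ccc(-n2cnc3c(F)cccc32)s1` has not yet been measured; it differs from compound 2 by hydrogen in place of methyl on an aromatic carbon. This is the same kind of change as that from compound 1 to compound 3, but the place differs: there the methyl sat on a five-membered aromatic ring with 2 nitrogen, between two ring nitrogen atoms, whereas here it sits on a six-membered aromatic ring of carbon only, meta to a fluoro group. Resting on a 2.0-fold higher number from compound 1 to compound 3 (0.30 log units; within the scatter), a step of a 1.4-fold higher number from compound 2 to compound 4 (0.15 log units; within the scatter) is expected. Compound 4 is therefore estimated at 14 mL/min/kg, most likely between 6 mL/min/kg and 30 mL/min/kg.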

Compound 4, clearance: 10 mL/min/kg
Compound 4: middle estimate off by 1.4-fold (0.15 log units), on the high side; the measured number falls inside the stated range.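

In this assay, hydrogen in place of methyl on an aromatic carbon of the six-membered ring gave no change at the digits printed from compound 2 to compound 4 (within the scatter). Set beside the earlier step, the result on the two cores does not separate from ordinary repeat variation: the same change on two cores in this assay, a 2.0-fold higher number (0.30 log units; within the scatter) from compound 1 to compound 3 and no change at the digits printed (within the scatter) from compound 2 to compound 4, 2.0-fold (0.30 log units) apart, within the scatter of two such steps This shows that the change carried across these two cores without a distinct difference, but it does not show that the step is the same, since neither step stands beyond the scatter, the methyl sits on a different ring in each core, and two pairs say nothing of other cores.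

The compounds shown leave open what an ethyl, a methoxy group or a chlorine in place of that methyl would do in this assay. They also leave open whether an amine or a carboxylic acid elsewhere on these cores would change the number.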